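Compound 3 to compound 4: losing the side group

The source may hold more compounds than are shown below. What is called first, only, known or untested is meant among the compounds shown, and "the series" means these compounds.

In an ADME assay on microsomes from liver (Mus musculus) for metabolic stability, read by LC-MS, with NADPH named in the record, with a stated time of 60 min, tested at 1 uM, in the absence of a further agent (on this read-out lower numbers stand for a less stable compound and higher numbers for a more stable compound), compound 1 `COc1ccc(-c2c(C)nc3c(N4CC[C@@H](NC(=O)c5ccccc5)C4)cc(C)nn23)cc1OC` gives > 95% as a limit of the assay. Compound 2 `COc1ccc(-c2c(C)nc3c(N4CC[C@@H](NS(C)(=O)=O)C4)cc(C)nn23)cc1OC` gives > 95% as a limit too. Compound 3 `COc1ccc(-c2c(C)nc3c(N4CC[C@@H](NS(=O)(=O)C5CC5)C4)cc(C)nn23)cc1OC` gives > 95% as a limit as well. The evidence so far is the limit of > 95% in this assay, at which 3 of the 3 values shown sit, and no more.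

Compound 4 `COc1ccc(-c2c(C)nc3c(N4CCCC4)cc(C)nn23)cc1OC` differs from compound 3 by hydrogen in place of (cyclopropylsulfonyl)amino on a saturated ring carbon in one change, hydrogen in place of (cyclopropylsulfonyl)amino on a saturated ring carbon.

Among the measured compounds shown here, three measured steps bear on it, namely a step that the two limits leave unreadable from compound 1 to compound 2 and a step that the two limits leave unreadable from compound 1 to compound 3 and a step that the two limits leave unreadable from compound 2 to compound 3 without a readable size. None of them removes the group outright.

Expected in this assay is a number at least 13 percentage points lower from compound 3 to compound 4 (beyond the scatter) as a downward move of uncertain size. Compound 4 is estimated at 82% with 55% to 98% as the expected range.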

Compound 4, percent of the compound remaining: > 95%
Compound 4 gave a limit, no number; the forecaster's own chance of this, stated with the estimate: 35%; at least 13 percentage points between middle value and limit.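

In this assay compound 4 gives > 95%, which is a limit. Among the compounds shown here, no step from compound 1, compound 2 or compound 3 to compound 4 can be read. The compounds shown leave open whether the side group on the saturated ring carbon changes the percent remaining at all, and the evidence stops at one shared limit: the limit of > 95% in this assay, at which 4 of the 4 values shown sit.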